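Nitro in place of chloro: expected cytotoxicity for compound 4

The source may hold more compounds than are shown below. What is called first, only, known or untested is meant among the compounds shown, and "the series" means these compounds.

Among the compounds with values here, the series so far holds compound 1 `Cc1cc(C)cc(S(=O)(=O)n2c(=S)[nH]c3ccc(Cl)cc32)c1`, compound 2 `Cc1cc(C)cc(Cn2c(SCC(=O)Nc3ccccc3Cl)nc3ccccc32)c1` and compound 3 `Cc1cc(C)cc(Cn2c(SCC(=O)Nc3ccccc3Cl)nc3ccc(Cl)cc32)c1`. In an ADME assay on MT4 cells (Homo sapiens) for cytotoxicity (a lower number here means that less compound is tolerated, a higher number that more compound is tolerated), compound 1 gives 93100 nM, compound 2 gives 111000 nM and compound 3 gives 141000 nM. Compound 2 stands second highest of the three numbers; its nearest neighbour is compound 1 and its furthest is compound 3, and both gaps lie within the scatter. Within the data shown here, the only single-point step recorded, a 1.3-fold higher number from compound 2 to compound 3 (0.10 log units; within the scatter), is chloro in place of hydrogen on an aromatic carbon of the shared core and does not move the number beyond the scatter.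

Compound 4 `Cc1cc(C)cc(Cn2c(SCC(=O)Nc3ccccc3[N+](=O)[O-])nc3ccccc32)c1` is not yet measured. It differs from compound 2 by nitro in place of chloro on an aromatic carbon; the place is an aromatic carbon of a six-membered aromatic ring of carbon only, ortho to a large group, so that 2-chlorophenyl becomes 2-nitrophenyl. Among the measured compounds shown here, no measured step swaps chloro for nitro, and the one step available, from hydrogen to chloro, stayed within the scatter. The expectation for compound 4 in this assay is therefore no step beyond the scatter, a 1.0-fold lower number from compound 2 to compound 4 (0.00 log units; within the scatter). Compound 4 is thus estimated at 110000 nM, with a range from 55000 nM to 220000 nM.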

Compound 4, half-maximal cytotoxic concentration: 194000 nM
Compound 4: the middle estimate sits 1.8-fold (0.25 log units) below what was measured; the range from low to high includes it.
By their numbers in this assay, from the lowest: compounds 1, 2, 3 and 4 (each within the scatter of the next, the first and the last beyond it).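

In this assay, within the data shown here, replacing 2-chlorophenyl with 2-nitrophenyl gives a 1.7-fold higher number from compound 2 to compound 4 (0.24 log units; within the scatter) and provides the first reading at this aromatic carbon ortho to a large group, since the only other single-point step, a 1.3-fold higher number from compound 2 to compound 3 (0.10 log units; within the scatter), lies on the shared core. At this position, chloro, with 1 heavy atom and 0 hydrogen-bond acceptors, gives way to nitro, with 3 heavy atoms and 2 hydrogen-bond acceptors, and the number still stays within the scatter, so neither single-point step in the series has yet gone beyond it. No measurement on hand bears on what lies behind this result.

On these data alone, whether an amine, a carboxylic acid or a methoxy group on the same aromatic carbon would also stay within the scatter of compound 2 remains open, as does the outcome with hydrogen there. Also open, as far as these compounds go, is whether nitro in place of chloro at this position would give a similar step on the chlorinated core of compound 3, and which single change, if any, would carry the number beyond the scatter.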